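Notes on the series: halophenyl change at the carbonyl carbon

The source may hold more compounds than are shown below. What is called first, only, known or untested is meant among the compounds shown, and "the series" means these compounds.

Measured so far:
compound 1 `O=C(/C=C/c1ccc(/C=N/NC(=O)c2ccncc2)cc1)c1ccc(Br)cc1` — 55.7%
compound 2 `O=C(N/N=C/c1ccc(/C=C/C(=O)c2ccc(Cl)cc2Cl)cc1)c1ccncc1` — 83.8%

In a functional assay on the whole organism (Ear) for inhibition, with Mus musculus as the target, with a stated time of 30 min, at a dose of 100 mg/kg by the intraperitoneal route (a lower number here means less inhibition, a higher number more inhibition at the dose given (going by the name of the read-out)), compound 2 gives 83.8%, the higher of the two numbers, while compound 1 gives 55.7%. Among the compounds with values here, the single step available, a number 28.1 percentage points higher from compound 1 to compound 2 (beyond the scatter), bears directly on the next one. Compound 3 `O=C(N/N=C/c1ccc(/C=C/C(=O)c2ccccc2Br)cc1)c1ccncc1` differs from compound 2 by 2-bromophenyl in place of 2,4-dichlorophenyl on a carbonyl carbon. Returning to a single bromine points back toward compound 1, yet 2-bromophenyl keeps part of the 2,4-dichlorophenyl pattern, so a partial reversal is expected rather than a full one. The expected step of a number 15.8 percentage points lower from compound 2 to compound 3 (beyond the scatter) is a moderate decrease. Compound 3 is estimated at 68%, with a range of 48% to 88%.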

Compound 3, a percentage reported as inhibition, in the whole organism at one dose (the size of the read-out at that dose, not a potency): 48.7%
For compound 3 the middle estimate is 19.3 percentage points above the measured one, within the range that was stated.
By their numbers in this assay, from the lowest: compounds 3 and 1 (each within the scatter of the next); then compound 2.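

In this assay, 2-bromophenyl in place of 2,4-dichlorophenyl on the carbonyl carbon does not retain the level of compound 2 (a number 35.1 percentage points lower from compound 2 to compound 3 (beyond the scatter)), so part of the earlier gain does not carry over to this single-bromine group. Changing 4-bromophenyl to 2-bromophenyl gives no separable change (a number 7 percentage points lower from compound 1 to compound 3 (within the scatter)), and the two bromophenyl compounds cannot be told apart here. No supporting measurement bears on why these groups differ.

The compounds shown leave open whether the high value of compound 2 needs both chlorines. A 2-chlorophenyl, 4-chlorophenyl or 2,4-dibromophenyl group on the same carbonyl carbon would address this.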